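Aryl amide swaps on the shared core: one number, two limits

The source may hold more compounds than are shown below. What is called first, only, known or untested is meant among the compounds shown, and "the series" means these compounds.

Measured so far in an assay on HEK293 cells for binding affinity to Urotensin-2 receptor (Homo sapiens), read by radioligand binding; on this read-out lower numbers stand for stronger inhibition and higher numbers for weaker inhibition:
compound 1 `CN(C)CCCOc1ccc(CN2CC[C@H](NC(=O)c3cc(Cl)cc(Cl)c3)C2)cc1`: 2000 nM
compound 2 `Cc1ccc(C(=O)N[C@H]2CCN(Cc3ccc(OCCCN(C)C)cc3)C2)cc1C`: a limit only, < 10000 nM
compound 3 `CN(C)CCCOc1ccc(CN2CC[C@H](NC(=O)c3ccco3)C2)cc1`: a limit only, < 10000 nM

Going by the values given here, compound 1 is the only compound with a readable number; the other two values are limits of the assay and not numbers. The change from compound 1 to compound 2 is 3,4-dimethylphenyl in place of 3,5-dichlorophenyl on a carbonyl carbon, and from compound 1 to compound 3 it is furan-2-yl in place of 3,5-dichlorophenyl at the same carbonyl carbon. Neither step can be sized, a step that the limit leaves unreadable from compound 1 to compound 2 and a step that the limit leaves unreadable from compound 1 to compound 3, since both partner values sit at the limit of < 10000 nM in this assay, at which 2 of the 3 values shown sit. The same holds for a step that the two limits leave unreadable from compound 2 to compound 3.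

Compound 4 `CN(C)CCCOc1ccc(CN2CC[C@H](NC(=O)c3ccc4ccccc4c3)C2)cc1` carries the change (naphthalen-2-yl in place of 3,5-dichlorophenyl on a carbonyl carbon). Among the compounds with values here, the two measured steps are the only ones that vary this aryl group on the carbonyl carbon, and both are unreadable, so no sized step supports a direction for compound 4. With nothing to set it apart, compound 4 is expected near compound 1, and the step of no change at the digits printed from compound 1 to compound 4 (within the scatter) is estimated to stay within the scatter, the range kept wide. Compound 4 is thus estimated at 2000 nM, between 400 nM and 9000 nM.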

Compound 4, inhibition constant: < 10000 nM
Compound 4 ended at the assay's limit; the forecaster's own chance of this, stated with the estimate: 25%; the middle value lies beyond the limit too.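

In this assay compound 4 gives < 10000 nM, a limit and not a number. None of the steps to compound 4 from compound 1, compound 2 or compound 3 can be read: the limit of < 10000 nM in this assay, at which 3 of the 4 values shown sit.

Compound 1 remains the only compound with a number, and the compounds shown leave open how far any other group on the carbonyl carbon moves the value.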